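Swapping the acetyl of compound 1 for a triazole

The source may report more compounds than this note shows. Statements on the series, on what has been measured and on what is new or still open speak of the compounds shown alone.

Of the compounds shown here, three that share the same core have been measured in an assay on membranes from brain for displacement of a labelled ligand from Neuronal acetylcholine receptor; alpha4/beta2 (Rattus norvegicus), with a stated time of 3 h; a lower number here means a stronger inhibitor, a higher number a weaker inhibitor. Compound 1 `CC(=O)c1ccc(/C=C2\CCCN=C2c2cccnc2)cc1` gives 4490 nM in this assay, the highest of the three numbers. Compound 2 `Cc1cc(O)cc(C)c1/C=C1\CCCN=C1c1cccnc1` gives 670 nM in this assay, and compound 3 `COc1ccc2cc(/C=C3\CCCN=C3c3cccnc3)ccc2c1` gives 600 nM in this assay; both of these lie beyond the usual scatter from compound 1, so compound 1 is the weakest binder among those measured.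

Compound 4 `C(=C1\CCCN=C1c1cccnc1)\c1ccc(-n2ccnn2)cc1` has not yet been measured. It differs from compound 1 in one place: 1H-1,2,3-triazol-1-yl in place of acetyl on an aromatic carbon. Going by the values given here, none of the measured compounds differ from one another by a single change, so there is no directly comparable step to lean on. What can be said is that the two compounds carrying groups other than acetyl on the attached ring, compound 2 and compound 3, both sit well below compound 1.

On that basis, compound 4 is expected to bind somewhat more strongly than compound 1, by the step of a 2.2-fold lower number from compound 1 to compound 4 (0.35 log units; beyond the scatter), though the size of the step is uncertain. The estimate for compound 4 in this assay is 2000 nM, with a range from 500 nM to 8000 nM.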

Compound 4, inhibition constant: 520 nM
For compound 4 the middle estimate is 3.8-fold (0.59 log units) above the measured one; the measured number falls inside the stated range.
By their numbers in this assay, from the lowest: compounds 4, 3 and 2 (each within the scatter of the next); then compound 1.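

In this assay, going by these compounds alone, putting 1H-1,2,3-triazol-1-yl in place of acetyl gives an 8.6-fold lower number from compound 1 to compound 4 (0.94 log units; beyond the scatter) and is the first change here that can be read on its own, since the two compounds differ in one place only. It shows that this aromatic carbon, para to a large group, accepts a five-membered aromatic ring with 3 hetero atoms, and that the acetyl is not needed for binding at this level. Nothing available here explains the gain.

Going by these compounds, it remains open whether this gain is particular to the triazole or would also appear with other groups at this position, such as an amine, a carboxylic acid or an amide. On these data alone, how a group placed elsewhere on this ring would compare also remains open.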